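A few compounds are considered here, and "the series" means these few. Any claim that something is new, unique, unknown or untested is made for them only; others in the source may bear on it.

Compound 1, `N#Cc1cc(-c2nc(C(c3ccc(F)cc3)c3ccc(F)cc3)sc2CC(=O)O)ccc1F`: 57 nM.
Compound 2, `Nc1nc(-c2ccc(Cl)cc2)c(CC(=O)O)s1`: > 100000 nM, a limit of the assay rather than a number.

The read-out throughout is an in vitro assay on HEK385-7 cells for displacement of a labelled ligand from prostaglandin D2 receptor 2 (Homo sapiens); on this read-out higher numbers stand for weaker inhibition and lower numbers for stronger inhibition. Among the measured compounds shown here, compound 1 stands as the only compound for which a number is given at all. For the measured compounds named here, for compound 2 the assay reports only a limit, (the limit of > 100000 nM in this assay, at which 1 of the 2 values shown sits), so no step between the two measured compounds can be sized, and the pair shows only that compound 1 gives a number while compound 2 does not.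

Compound 3, `O=C(O)Cc1sc(C(c2ccc(F)cc2)c2ccc(F)cc2)nc1-c1ccco1`, has not yet been measured in this assay. It differs from compound 1 in one place: furan-2-yl in place of 3-cyano-4-fluorophenyl on an aromatic carbon. With no measured step between compounds that differ in one place, the size of the step from compound 1 to compound 3 cannot be read from the data; the expectation is a moderate loss, going beyond the usual scatter toward weaker inhibition, and the starting point is compound 1, which gives the only number shown, 57 nM. Compound 3 is therefore expected to give about 300 nM in this assay, with the estimate spanning 60 nM to 2000 nM. The step of a 5.3-fold higher number from compound 1 to compound 3 (0.72 log units; beyond the scatter) is the one this estimate implies.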

Compound 3, half-maximal inhibitory concentration: 18 nM
Compound 3: middle estimate off by 17-fold (1.22 log units), on the high side; measured number outside the range, below it.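

In this assay, among the compounds shown here, this is the first step that can be sized at the aromatic carbon next to the ring nitrogen, and furan-2-yl in place of 3-cyano-4-fluorophenyl gives a 3.2-fold lower number from compound 1 to compound 3 (0.50 log units; beyond the scatter). The comparison shows that, on the core of compound 1, this position does not depend on a six-membered aromatic ring carrying a nitrile and a fluorine, since the five-membered aromatic ring of compound 3 gives 18 nM. Nothing measured among the compounds shown accounts for this step.

For the compounds shown here, the single pair leaves open whether the step belongs to the furan-2-yl ring itself or to the loss of the nitrile and fluorine, a question that an unsubstituted phenyl or a thiophen-2-yl at the same position would address. Steps involving compound 2 cannot be read, as it differs from the others in more than one place, and the effect of furan-2-yl on any other core, or with an amine or a longer chain in place of the carboxymethyl group, remains unknown.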